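The source may hold more compounds than are shown below. What is called first, only, known or untested is meant among the compounds shown, and "the series" means these compounds.

Compound 1 `O=C(OC1(C(=O)Nc2ccc([N+](=O)[O-])cc2)CCCCC1)c1ccc(Cl)cc1` gives 10.3 nM in a functional assay on NFS-60 cells (Mus musculus) for inhibition, read by MTT assay, with a stated time of 72 h; on this read-out higher numbers stand for weaker inhibition and lower numbers for stronger inhibition. Compound 2 `O=C(OC1(C(=O)Nc2ccc([N+](=O)[O-])cc2)CCCCC1)c1ccc(Br)cc1` gives 236 nM in this assay. Compound 3 `CCOC(=O)c1ccccc1C(=O)OC1(C(=O)Nc2ccc([N+](=O)[O-])cc2)CCCCC1` gives 488 nM in this assay.

Compound 2 stands second highest of these three numbers: compound 3 is somewhat higher, and compound 1 far lower, the measured step between them being a 23-fold higher number from compound 1 to compound 2 (1.36 log units; beyond the scatter). Compound 4 `O=C(OC1(C(=O)Nc2ccc([N+](=O)[O-])cc2)CCCCC1)c1ccccc1` differs from compound 2 by hydrogen in place of bromo on an aromatic carbon. Within the data shown here, only one measured step touches this position, a 23-fold higher number from compound 1 to compound 2 (1.36 log units; beyond the scatter), a large change from one halogen to another. Among the measured compounds shown here, no measured compound shows what hydrogen does at that place, so the direction is uncertain. Since compound 2 sits far from compound 1 because of a 23-fold higher number from compound 1 to compound 2 (1.36 log units; beyond the scatter), compound 4 is expected to move back toward a lower number, a 3.9-fold lower number from compound 2 to compound 4 (0.59 log units; beyond the scatter), with wide uncertainty. Compound 4 is estimated at 60 nM, between 12 nM and 300 nM.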

Compound 4, half-maximal inhibitory concentration: 766 nM
The estimate for compound 4 lay 13-fold (1.11 log units) below the measured number; measured number outside the range, above it.
By their numbers in this assay, from the lowest: compound 1; then compound 2; then compounds 3 and 4 (each within the scatter of the next).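

Putting hydrogen in place of the halogen does not bring the number back down: the data show a 3.2-fold higher number from compound 2 to compound 4 (0.51 log units; beyond the scatter) and a 74-fold higher number from compound 1 to compound 4 (1.87 log units; beyond the scatter) in this assay, so chloro stands well apart from both bromo and hydrogen at this place. Hydrogen in place of ethoxycarbonyl gives a 1.6-fold higher number from compound 3 to compound 4 (0.20 log units; within the scatter), a step within the scatter. No evidence at hand explains why chloro stands apart.

As far as these compounds go, how fluoro, a methyl group or an amine would compare at this place stays open. So does whether any group other than chloro can reach a number as low as that of compound 1.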